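This account rests on a few compounds, and the source may have more. Where it says the series, first, only, none or still open, it means among the compounds named here.

Measured compounds:
compound 1, `CCCc1nc(-c2ccccc2)c(CNCCCN2CCN(c3cccc(F)c3)CC2)o1`: 3030 nM in an assay on HEK293 cells for inhibition of Voltage-dependent T-type calcium channel subunit alpha-1G (Homo sapiens), read by patch clamp; on this read-out higher numbers stand for weaker inhibition and lower numbers for stronger inhibition
compound 2, `CCCc1nc(-c2ccccc2)c(CNCCN2CCN(c3cccc(C)c3C)CC2)o1`: 1710 nM in this assay

For the measured compounds named here, compound 1 gives the highest of the two numbers so far, yet the only other value, that of compound 2, lies within the usual scatter of it; no step between two measured compounds that differ in one place is available in this set, so the position of compound 1 rests on these two values alone and nothing about a trend can be read from them.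

Compound 3, `CCCc1nc(-c2ccccc2)c(CNCCCN2CCN(c3ccccc3F)CC2)o1`, is the next compound for this assay. It keeps the same atoms as compound 1, joined differently: 2-fluorophenyl in place of 3-fluorophenyl on an amine nitrogen in a ring. Going by the values given here, the data hold no pair that isolates this kind of move, so there is no measured basis for a direction.

Compound 3 is therefore expected to stay close to compound 1, with a step of a 1.0-fold lower number from compound 1 to compound 3 (0.00 log units; within the scatter) that is estimated to remain within the scatter in either direction. For compound 3 the estimated value in this assay is 3000 nM, with a range from 1200 nM to 8000 nM.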

Compound 3, half-maximal inhibitory concentration: 16100 nM
The estimate for compound 3 lay 5.4-fold (0.73 log units) below the measured number; measured number outside the range, above it.
By their numbers in this assay, from the lowest: compounds 2 and 1 (each within the scatter of the next); then compound 3.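

In this assay, 2-fluorophenyl in place of 3-fluorophenyl on an amine nitrogen in a ring gives a 5.3-fold higher number from compound 1 to compound 3 (0.73 log units; beyond the scatter), a change beyond the scatter towards weaker inhibition. For the compounds shown here, this is the first reading at this position, and it shows that inhibition can respond to where the fluorine stands on the phenyl group alone, since the group that leaves and the group that enters have the same counts of heavy atoms, hydrogen-bond donors and hydrogen-bond acceptors. Nothing available bears on what lies behind this step, so it stands as an observation only.

The compounds shown leave open whether the step is particular to fluorine, as a 2-chlorophenyl, a 2-methoxyphenyl or a plain phenyl group at the same place would be needed to tell. They also leave open whether the swap from 3-fluorophenyl to 2-fluorophenyl keeps its size on a longer chain, as this single pair rests on one chain and one core.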